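Removing the amino group at the assay limit

This account rests on a few compounds, and the source may have more. Where it says the series, first, only, none or still open, it means among the compounds named here.

In a functional assay on Bel-7402 cells (Homo sapiens) for inhibition, read by sulforhodamine B assay, with a stated time of 72 h (a lower number here means a stronger inhibitor, a higher number a weaker inhibitor), compound 1 `C[C@H](Nc1ncnc2[nH]cnc12)c1nn(-c2cccc(F)c2)c2cc(F)ccc12` gives > 40000 nM, a limit of the assay and not a number. Compound 2 `C[C@H](Nc1nc(N)nc2[nH]cnc12)c1nn(-c2cccnc2)c2cc(F)ccc12` gives > 40000 nM, also a limit and not a number. Among the measured compounds shown here, compound 2 therefore has no numerical potency to start from, and the series so far comes to the limit of > 40000 nM in this assay, at which 2 of the 2 values shown sit. For the measured compounds named here, no step between measured compounds is available to size a change.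

Compound 3 `C[C@H](Nc1ncnc2[nH]cnc12)c1nn(-c2cccnc2)c2cc(F)ccc12` follows from compound 2 with hydrogen in place of amino on an aromatic carbon, between two ring nitrogen atoms: hydrogen in place of amino on an aromatic carbon. In this assay, no step beyond the usual scatter is expected, and two limits show no direction. The expected change, a number no higher from compound 2 to compound 3 (the limit leaves the size open), is an estimate only. For compound 3 the estimated value is 40000 nM, with an expected range of 20000 nM to 60000 nM, and another report as a limit is likely.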

Compound 3, half-maximal inhibitory concentration: > 40000 nM
Compound 3: no number, only a limit; the forecaster's own chance of this, stated with the estimate: 85%; the middle value sits exactly at the limit.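

Compound 3 gives > 40000 nM in this assay, a limit and not a number. The steps to it from compound 2 and from compound 1 cannot be read. The compounds shown leave open whether hydrogen in place of amino or pyridin-3-yl in place of 3-fluorophenyl changes potency at all, with the series resting on one figure: the limit of > 40000 nM in this assay, at which 3 of the 3 values shown sit.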